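The source may report more compounds than this note shows. Statements on the series, on what has been measured and on what is new or still open speak of the compounds shown alone.

Measured so far in a functional assay on MDA-MB-231 cells (Homo sapiens) for cytotoxicity, with a stated time of 48 h; a lower number here means a stronger inhibitor, a higher number a weaker inhibitor:
- compound 1 `COc1cc(O)c(C(=O)/C=C/c2ccc(F)cc2)c(OC)c1`: > 20000 nM, a limit of the assay and not a number
- compound 2 `COc1cc(OC)c(C(=O)/C=C/c2ccccc2SC)c(OC)c1`: 9900 nM
- compound 3 `COc1cc(OC)c(C(=O)/C=C/c2ccc([N+](=O)[O-])cc2)c(OC)c1`: 3300 nM

Only two of these results are numbers. Of the two, compound 2 at 9900 nM has the higher value, so it is the weaker inhibitor of the pair. Compound 3 at 3300 nM has the lower value, and the gap lies beyond the scatter. Within the data shown here, no measured pair differs in one place only, so the series offers no direct step to draw on.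

Next is compound 4 `COc1cc(OC)c(C(=O)/C=C/c2ccc(Br)cc2)c(OC)c1`, which has the same core as compound 2 and compound 3. It carries 4-bromophenyl in place of 2-(methylsulfanyl)phenyl on a double-bonded chain carbon bound to a double-bonded chain carbon.

With so little to go on, compound 4 is expected to fall between the two numbers, given compound 3 at 3300 nM on the same core. The expected change is small and may not clear the scatter: a 2.0-fold lower number from compound 2 to compound 4 (0.30 log units; within the scatter). For compound 4 the estimated value is 5000 nM, with an expected range of 1800 nM to 14000 nM.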

Compound 4, half-maximal inhibitory concentration: 11100 nM
Compound 4: middle estimate off by 2.2-fold (0.35 log units), on the low side, within the range that was stated.
By their numbers in this assay, from the lowest: compound 3; then compounds 2 and 4 (each within the scatter of the next). At a limit, above all of these: compound 1.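

In this assay, 4-bromophenyl in place of 2-(methylsulfanyl)phenyl on a double-bonded chain carbon bound to a double-bonded chain carbon gives no readable change (a 1.1-fold higher number from compound 2 to compound 4 (0.05 log units; within the scatter)), so this position accepts the exchange of these two groups without a shift beyond the scatter. Bromo in place of nitro on an aromatic carbon does give a step beyond the scatter, though a modest one (a 3.4-fold higher number from compound 3 to compound 4 (0.53 log units; beyond the scatter)), which makes compound 3 and compound 4 the one pair shown where a single change registers in this assay. Nothing available here accounts for either step.

Going by these compounds, whether other groups on that aromatic carbon, such as an amine or a carboxylic acid, would follow nitro or bromo remains open. Also open, on these data alone, is whether 4-bromophenyl would behave the same way on the core of compound 1, with its hydroxyl group.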